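Swapping a Ring Pendant Under a Cytotoxicity Screen

The compounds below may be only part of what the source reports. "The series", "measured", "known", "first", "only" and "open" are said of these compounds alone.

Compound 1 `CC(C)N(Cc1cccc(OCCCCCC(=O)O)c1)C(=O)c1ccc(-c2cccc(OC(F)(F)F)c2)cc1` was tested in an ADME assay on BJ cells (Homo sapiens) for cytotoxicity, read by CellTiter-Glo and resazurin assay, with a stated time of 72 h; a lower number here means that less compound is needed, a higher number that more compound is needed for the effect. In this assay compound 1 gives only a limit, > 26000 nM. Compound 2 `COc1cc(F)cc(-c2ccc(C(=O)N(Cc3cccc(OCCCCCC(=O)O)c3)C(C)C)cc2)c1` differs from it by 3-fluoro-5-methoxyphenyl in place of 3-(trifluoromethoxy)phenyl on an aromatic carbon. In this assay compound 2 also gives only a limit, > 26000 nM. The step that the two limits leave unreadable from compound 1 to compound 2 cannot be sized because of the limit of > 26000 nM in this assay, at which 3 of the 3 values shown sit.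

Compound 3 `CCOC(=O)CCCCCOc1cccc(CN(C(=O)c2ccc(-c3cccc(OC(F)(F)F)c3)cc2)C(C)C)c1` has a core that differs from the core of compound 1 by ethyl in place of hydrogen on an oxygen next to a carbonyl group. In this assay compound 3 gives only a limit, > 26000 nM.

Compound 4 `CCOC(=O)CCCCCOc1cccc(CN(C(=O)c2ccc(-c3cc(F)cc(OC)c3)cc2)C(C)C)c1` is not yet measured and differs from compound 3 by 3-fluoro-5-methoxyphenyl in place of 3-(trifluoromethoxy)phenyl on an aromatic carbon, the same change as from compound 1 to compound 2, at the same place. Beside the unreadable earlier step that the two limits leave unreadable from compound 1 to compound 2, the new step is expected to read a step that the limit leaves unreadable from compound 3 to compound 4 because of the limit of > 26000 nM in this assay, at which 3 of the 3 values shown sit. Compound 4 in this assay is therefore estimated at 45000 nM, most likely again reported only as a limit.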

Compound 4, half-maximal effective concentration: > 26000 nM
Compound 4 was reported as a limit (the forecaster's own chance of this, stated with the estimate: 85%); the middle value does not contradict the limit.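

The steps from compound 2 and from compound 3 to compound 4 cannot be read, because every result is a limit: the limit of > 26000 nM in this assay, at which 4 of the 4 values shown sit.

From the compounds shown here alone, whether either the ring swap or the ethyl group changes the effect in this assay stays open.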